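Trifluoromethyl for cyano: from compound 2 to compound 4

The source may report more compounds than this note shows. Statements on the series, on what has been measured and on what is new or still open speak of the compounds shown alone.

In a functional assay on HeLa cells (Homo sapiens) for antiproliferative activity, read by sulforhodamine B assay, with a stated time of 72 h (a lower number here means a stronger inhibitor, a higher number a weaker inhibitor), compound 2 `N#Cc1ccc(NC(=S)N/N=C/c2ccc3ccccc3n2)cc1` stands lowest of the two numbers shown, giving 20000 nM. Compound 1 `COc1cccc(NC(=S)N/N=C/c2ccc3ccccc3n2)c1` gives 74500 nM in this assay. For compound 3 `S=C(N/N=C/c1ccc2ccccc2n1)Nc1ccccc1Br` this assay reports only a limit, > 100000 nM (the limit of > 100000 nM in this assay, at which 1 of the 3 values shown sits). The measured steps all change the ring on the amide-type nitrogen: a 3.7-fold lower number from compound 1 to compound 2 (0.57 log units; beyond the scatter), and an at least 5.0-fold higher number from compound 2 to compound 3 (0.69 log units; beyond the scatter). Compound 4 `FC(F)(F)c1ccc(NC(=S)N/N=C/c2ccc3ccccc3n2)cc1` differs from compound 2 by trifluoromethyl in place of cyano on an aromatic carbon. Going by the values given here, no measured step exchanges one group for another on this ring, so the precedent is indirect; the steps that do bear show modest movement when the ring is varied. Compound 4 is therefore expected to be a somewhat weaker inhibitor, a 1.5-fold higher number from compound 2 to compound 4 (0.18 log units; within the scatter). The estimate for compound 4 is 30000 nM, with a range from 10000 nM to 100000 nM.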

Compound 4, half-maximal inhibitory concentration: 59100 nM
The estimate for compound 4 lay 2.0-fold (0.29 log units) below the measured number, within the range that was stated.
By their numbers in this assay, from the lowest: compound 2; then compounds 4 and 1 (each within the scatter of the next). At a limit, above all of these: compound 3.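

In this assay, going by these compounds alone, a 3.0-fold higher number from compound 2 to compound 4 (0.47 log units; beyond the scatter) is the first step that exchanges one group for another at a single place, an aromatic carbon para to a large group. Within the data shown here, the reading at this place therefore depends on the group it carries, even with the place held fixed, something the earlier steps could not separate because each also moved the substituent. Nothing in the data available bears on why this step has this size. From the compounds shown here alone, how an unsubstituted phenyl ring, an amine or a carboxylic acid at this place would read stays open. Among these compounds, with only two groups compared here, no trend across groups can be drawn for this place.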